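This account rests on a few compounds, and the source may have more. Where it says the series, first, only, none or still open, it means among the compounds named here.

Three compounds with a shared core are considered here. Compound 1 `COc1cc(-c2nnc(SCC(=O)c3ccc(Cl)cc3)n2N)cc(OC)c1OC` carries a (4-chlorophenyl)carbonyl group on the thioether chain, but in an ADME assay on HEK293 cells (Homo sapiens) for cytotoxicity, read by MTT assay, with a stated time of 48 h (on this read-out lower numbers stand for stronger inhibition and higher numbers for weaker inhibition), compound 1 has only the entry "not determined" (no result reported) and no result recorded. Compound 2 `COc1cc(-c2nnc(SCC(=O)c3ccc(C)cc3)n2N)cc(OC)c1OC` carries a (4-methylphenyl)carbonyl group in the same position, and in this assay compound 2 gives 100000 nM. Among the measured compounds shown here, that is the only number available in this assay, so compound 2 stands alone, with compound 1 beside it as an entry without a value; no comparison between measured compounds can be drawn.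

Compound 3 `COc1cc(-c2nnc(SCC(=O)Nc3ccccc3F)n2N)cc(OC)c1OC` is the compound to be measured next. It differs from compound 2 in one place: (2-fluorophenyl)amino in place of 4-methylphenyl on a carbonyl carbon. For the measured compounds named here, since no measured pair shows what such a change does in this assay, the expectation rests on compound 2 alone. The step of no change at the digits printed from compound 2 to compound 3 (within the scatter) is expected to be small, within the scatter rather than beyond it, with no clear direction. Compound 3 is therefore estimated at 100000 nM in this assay, in the range from 50000 nM to 200000 nM.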

Compound 3, half-maximal inhibitory concentration: > 100000 nM
Compound 3 ended at the assay's limit; the forecaster's own chance of this, stated with the estimate: 35%; the middle value sits exactly at the limit.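

In this assay compound 3 gives > 100000 nM, which is a limit of the assay and not a number. Placing (2-fluorophenyl)amino, which brings a hydrogen-bond donor, in place of 4-methylphenyl on a carbonyl carbon gives a number no lower from compound 2 to compound 3 (the limit leaves the size open), so this change brings no sign of stronger inhibition, something compound 2 alone could not show. The read-out gives no more than this, and the result sits at the edge of what the assay reports: the limit of > 100000 nM in this assay, at which 1 of the 3 values shown sits.

From the compounds shown here alone, whether a simple amine or a carboxylic acid on this carbonyl carbon, or a longer chain in that place, would give a lower number in this assay stays open. Also open, going by these compounds, is how far compound 3 actually lies from compound 2, and whether any group at this position can move the read-out away from the top of its range.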